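This account rests on a few compounds, and the source may have more. Where it says the series, first, only, none or still open, it means among the compounds named here.

Measured in a toxicity assay on HepG2 2.2.15 cells (Homo sapiens) for cytotoxicity, read by CellTiter-Glo; on this read-out lower numbers stand for higher toxicity in this test and higher numbers for lower toxicity in this test:
Compound 1 `N#CC1CC(=O)N(c2cnn3c2CN(C(=O)Nc2cc(F)c(F)c(F)c2)C(C2CC2)C3)C1`: > 200000 nM, a limit of the assay
Compound 2 `O=C1CC(Oc2ncc(F)cn2)CN1c1cnn2c1CN(C(=O)Nc1cc(F)c(F)c(F)c1)C(C1CC1)C2`: 96200 nM
Compound 3 `O=C1c2ccccc2CN1c1cnn2c1CN(C(=O)Nc1cc(F)c(F)c(F)c1)C(C1CC1)C2`: 38500 nM

Compound 3, at 38500 nM, has the lowest number of the three, and compound 2 gives 96200 nM. Compound 4 `O=C1CC(c2ncccn2)CN1c1cnn2c1CN(C(=O)Nc1cc(F)c(F)c(F)c1)C(C1CC1)C2` has not yet been measured. It carries 2-oxo-4-(pyrimidin-2-yl)pyrrolidin-1-yl on the aromatic carbon where compound 3 carries its own group: a group of 12 heavy atoms (8 carbon, 3 nitrogen, 1 oxygen; one five-membered non-aromatic ring with 1 hetero atom, one six-membered aromatic ring with 2 hetero atoms) in place of a group of 10 heavy atoms (8 carbon, 1 nitrogen, 1 oxygen; one five-membered non-aromatic ring with 1 hetero atom, one six-membered aromatic ring of carbon only), on an aromatic carbon.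

Going by the values given here, two measured steps bear on this change, and both start from the limit of compound 1. The larger is an at least 5.1-fold lower number from compound 1 to compound 3 (0.71 log units; beyond the scatter), and it leads to the group that compound 4 gives up. The smaller is an at least 2.0-fold lower number from compound 1 to compound 2 (0.31 log units; beyond the scatter), and it leads to a group that, like the entering one, holds a pyrimidine ring on the five-membered non-aromatic ring. Compound 4 is therefore expected to lie nearer compound 2, at 96200 nM, than compound 3.

The expected change is a 2.5-fold higher number from compound 3 to compound 4 (0.39 log units; beyond the scatter), a modest rise in the number. For compound 4 the estimated value is 95000 nM, with an expected range of 40000 nM to 200000 nM.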

Compound 4, half-maximal cytotoxic concentration: > 200000 nM
Compound 4: no number, only a limit; the forecaster's own chance of this, stated with the estimate: 30%; middle value at least 2.1-fold (0.32 log units) from the limit.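

In this assay compound 4 gives > 200000 nM, which is a limit of the assay and not a number. The earlier steps shown here at this position all led downward, whereas 2-oxo-4-(pyrimidin-2-yl)pyrrolidin-1-yl in place of the group of compound 3 brings an at least 5.1-fold higher number from compound 3 to compound 4 (0.71 log units; beyond the scatter), and pyrimidin-2-yl in place of (5-fluoropyrimidin-2-yl)oxy on the saturated ring carbon brings an at least 2.0-fold higher number from compound 2 to compound 4 (0.31 log units; beyond the scatter), so a pyrimidine ring on the five-membered non-aromatic ring does not by itself go with a lower number. The step between compound 1 and compound 4 cannot be read: the limit of > 200000 nM in this assay, at which 2 of the 4 values shown sit.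

The step from compound 2 to compound 4 removes the linking oxygen and the fluorine together, so the share of each remains unresolved. From the compounds shown here alone, how an amine or a carboxylic acid on that saturated ring carbon would read in this assay also stays open.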